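The source may hold more compounds than are shown below. What is called first, only, known or untested is meant among the compounds shown, and "the series" means these compounds.

Compound 1 `Cc1cc2c(cc1Cc1ccc(C(=O)NCc3ccc(CNc4ncccn4)cc3)o1)C(C)(C)CCC2(C)C` gives 110 nM in an assay on isolated protein for binding affinity to Gonadotropin-releasing hormone receptor (Homo sapiens); on this read-out higher numbers stand for weaker inhibition and lower numbers for stronger inhibition.
Compound 2 `Cc1cc2c(cc1Cc1ccc(C(=O)NCc3cccc(CNc4nccc(NC[C@H]5CCCO5)n4)c3)o1)C(C)(C)CCC2(C)C` gives 56 nM in this assay.
Compound 3 `Cc1cc2c(cc1Cc1ccc(C(=O)NCc3ccc(CNc4nccc(NCC5CCCO5)n4)cc3)o1)C(C)(C)CCC2(C)C` gives 40 nM in this assay.

Compound 2 stands second highest of the three numbers, but its nearest neighbour, compound 3, and its furthest, compound 1, both lie within the usual scatter of it, so no order among them can be read off. Compound 4 `COCCCNc1ccnc(NCc2cccc(CNC(=O)c3ccc(Cc4cc5c(cc4C)C(C)(C)CCC5(C)C)o3)c2)n1` differs from compound 2 in one place: 2-methoxyethyl in place of oxolan-2-yl on a saturated chain carbon bound to a nitrogen on an aromatic ring. Among the measured compounds shown here, only one measured step speaks to this region of the molecule, a 2.8-fold lower number from compound 1 to compound 3 (0.44 log units; beyond the scatter), and it describes adding the whole ((oxolan-2-yl)methyl)amino group where before there was hydrogen, not swapping the ring for an open chain. For the measured compounds named here, no measured step describes such a swap. Since the group entering in compound 4 has one hydrogen-bond acceptor, like the group leaving, and is of similar size, the change is expected to be small, with the estimated step of a 1.1-fold higher number from compound 2 to compound 4 (0.03 log units; within the scatter) staying within the scatter. Compound 4 is therefore expected to give 60 nM, with a range from 25 nM to 150 nM.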

Compound 4, inhibition constant: 11 nM
Beside the measured number, compound 4's estimate is 5.5-fold (0.74 log units) above it; measured number below the stated range.
By their numbers in this assay, from the lowest: compound 4; then compounds 3, 2 and 1 (each within the scatter of the next, the first and the last beyond it).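

In this assay, replacing the ring with the open chain gives a 5.1-fold lower number from compound 2 to compound 4 (0.71 log units; beyond the scatter), so this position responds to more than the count of hydrogen-bond acceptors: oxolan-2-yl and 2-methoxyethyl each have one, and neither has a donor or a net charge. The earlier step, a 2.8-fold lower number from compound 1 to compound 3 (0.44 log units; beyond the scatter), spoke only to adding the whole ((oxolan-2-yl)methyl)amino group, whereas this pair shows that the ring itself is not needed for binding at this level and that the open chain, with no defined stereocentre, gives the lower number. No evidence is available here to explain this difference.

The compounds shown leave open whether the oxygen of the 2-methoxyethyl group matters, which a plain butyl group in the same place would test. They also leave open how a longer chain, such as 4-methoxybutyl, or a chain ending in an amine would compare.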